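This account rests on a few compounds, and the source may have more. Where it says the series, first, only, none or still open, it means among the compounds named here.

Measured in a functional assay on HCT-116 cells (Homo sapiens) for antiproliferative activity, read by MTT assay, with a stated time of 48 h; a higher number here means a weaker inhibitor, a lower number a stronger inhibitor:
Compound 1 `CCCCCC(CCO)n1cnc2c(Cl)ncnc21`; compound 1 gives > 50000 nM, a limit of the assay.
Compound 2 `CCCCCC(CCO)n1cnc2cncnc21`; compound 2 gives > 50000 nM, also a limit.
Compound 3 `CCCCCCCCCC(CCO)n1cnc2c(Cl)ncnc21`; compound 3 gives 890 nM.

Compound 4 `CCCCCCCCCC(CCO)n1cnc2c(Cl)nc(Cl)nc21` is not yet measured in this assay. The change from compound 3 to compound 4 is chloro in place of hydrogen on an aromatic carbon. The same kind of change runs from compound 2 to compound 1, (chloro in place of hydrogen on an aromatic carbon), but the surroundings differ: in compound 1 the chloro sits next to the ring nitrogen, ortho to a fused ring, meta to a fused ring, opposite the ring nitrogen, whereas in compound 4 it sits between two ring nitrogen atoms, meta to a chloro group, meta to a fused ring, para to a fused ring. That earlier step, a step that the two limits leave unreadable from compound 2 to compound 1, stays unreadable because both compounds sit at the limit of > 50000 nM in this assay, at which 2 of the 3 values shown sit. The difference between the cores of compound 2 and compound 3 is not broken down here. The step of an at least 56-fold lower number from compound 1 to compound 3 (1.74 log units; beyond the scatter) is large. The matching chloro step gives no size, so the expectation for compound 4 leans on compound 3 alone. For compound 4 the expected step is a 1.8-fold lower number from compound 3 to compound 4 (0.25 log units; within the scatter), a modest one. Compound 4 is thus estimated at 500 nM, within roughly 150 nM to 2000 nM.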

Compound 4, half-maximal inhibitory concentration: 32600 nM
For compound 4 the middle estimate is 65-fold (1.81 log units) below the measured one; measured number above the stated range.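

In this assay, a chloro group placed between two ring nitrogen atoms on the longer-chain core gives a 37-fold higher number from compound 3 to compound 4 (1.56 log units; beyond the scatter), a large loss at this one place on this one core. Among these compounds, the only other chloro step, from compound 2 to compound 1, cannot be read, since both compounds sit at a limit: the limit of > 50000 nM in this assay, at which 2 of the 4 values shown sit. That step also puts the chloro at a different place on the ring, so these data do not show whether a chloro change carries from one core to another.

Open, on these data alone, is how an amine at the same place would read against compound 3. Also open, as far as these compounds go, is whether a longer chain would change the reading of compound 4.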